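A few compounds are considered here, and "the series" means these few. Any claim that something is new, unique, unknown or untested is made for them only; others in the source may bear on it.

Three compounds share one core and differ only in the aromatic ring attached to the nitrogen of the five-membered ring. Compound 1 `Cc1ccc(-n2nc(-c3ccc(C(F)(F)F)cc3O)nc2-c2ccccc2O)cc1` carries a methyl on that ring, compound 2 `Oc1cc(C(F)(F)F)ccc1-c1nc(-c2ccccc2O)n(-c2ccc(Cl)cc2)n1` a chloro, and compound 3 `Oc1cc(C(F)(F)F)ccc1-c1nc(-c2ccccc2O)n(-c2ccc(I)cc2)n1` an iodo. In a functional assay on PC-12 cells (Rattus norvegicus) for cytotoxicity, read by MTT assay, with stated times of 2 h and 24 h, tested at 5 uM (on this read-out higher numbers stand for a stronger effect at the one concentration tested and lower numbers for a weaker effect), compound 1 gives 94.1%, compound 2 gives 87.3% and compound 3 gives 94.4%. The swaps between them are small: a number 6.8 percentage points lower from compound 1 to compound 2 (within the scatter), a number 0.3 percentage points higher from compound 1 to compound 3 (within the scatter) and a number 7.1 percentage points higher from compound 2 to compound 3 (within the scatter). Compound 3 therefore holds the highest of the three numbers, yet neither of its partners lies beyond the scatter of it, so the three are best read as one level.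

Compound 4 `Oc1cc(C(F)(F)F)ccc1-c1nc(-c2ccccc2O)n(-c2cccc(C(F)(F)F)c2)n1` is the next step: 3-(trifluoromethyl)phenyl in place of 4-iodophenyl on an aromatic nitrogen. Among the measured compounds shown here, every measured step so far changed a group on this same aromatic ring, and none of them moved this assay beyond the scatter, so the same is expected here. Compound 4 is expected to give a step of a number 4.4 percentage points lower from compound 3 to compound 4 (within the scatter), meaning no real change. The estimate for compound 4 in this assay is 90%, with a range from 78% to 98%.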

Compound 4, a percentage reported as activity, at one concentration (the size of the read-out at that concentration, not a potency): 92.2%
Compound 4: middle estimate off by 2.2 percentage points, on the low side; measured number inside the range.
By their numbers in this assay, from the lowest: compounds 2, 4, 1 and 3 (each within the scatter of the next).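

In this assay, the change to 3-(trifluoromethyl)phenyl gives a number 2.2 percentage points lower from compound 3 to compound 4 (within the scatter), a number 4.9 percentage points higher from compound 2 to compound 4 (within the scatter) and a number 1.9 percentage points lower from compound 1 to compound 4 (within the scatter), so all four compounds read as one level. Among the compounds shown here, compound 4 is the first here in which the group on this aromatic ring is not in the 4 position of the phenyl, and the substituent on the aromatic nitrogen also grows from 7 to 10 heavy atoms when 4-iodophenyl leaves, so this position tolerates both a shift of the group around the ring and a larger group without a step beyond the scatter. No measurement here gives a reason for this flat picture.

The compounds shown leave open how a 4-(trifluoromethyl)phenyl group would read, which would separate the effect of the group itself from the effect of where it sits on the ring. They also leave open whether the same level would hold with an amine or a carboxylic acid on this ring, or with a longer chain in place of the ring, and a reading at one concentration cannot rank these compounds by potency.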